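Halogen swap on the benzyl ether of a cyclic sulfonate

The source may hold more compounds than are shown below. What is called first, only, known or untested is meant among the compounds shown, and "the series" means these compounds.

Measured so far:
- compound 1, `CCC1(Cc2ccccc2)OS(=O)(=O)C=C1OCc1ccc(F)cc1`: >= 50000 nM
- compound 2, `CCCC1(Cc2ccccc2)OS(=O)(=O)C=C1OCc1ccccc1`: >= 400000 nM
- compound 3, `CCC1(CC)OS(=O)(=O)C=C1OCc1ccccc1`: > 400000 nM

Three compounds sharing one core have been run through an ADME assay on HEL cells (Homo sapiens) for cytotoxicity, with a stated time of 3 days; a higher number here means that more compound is tolerated, a lower number that less compound is tolerated. For compound 1 the result is a limit of the assay, not a number: >= 50000 nM. Compound 2 likewise stands at a limit, >= 400000 nM. Compound 3 also stands at a limit, > 400000 nM. Because every value shown is a limit, none of the three can be ordered against the others, and compound 1 can only be said to sit at the lower of the limits that appear, (the limit of >= 50000 nM in this assay, at which 1 of the 3 values shown sits), while the other two sit at the limit of > 400000 nM in this assay, at which 1 of the 3 values shown sits, and (the limit of >= 400000 nM in this assay, at which 1 of the 3 values shown sits).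

Compound 4, `CCC1(Cc2ccccc2)OS(=O)(=O)C=C1OCc1ccc(Br)cc1`, has not yet been measured in this assay. It differs from compound 1 in one place: bromo in place of fluoro on an aromatic carbon.

Among the measured compounds shown here, no step between measured compounds is available to calibrate this change, and the values of compounds 1 to 3 are limits only. The expectation is therefore that compound 4 will show no step beyond the scatter from compound 1, and the estimated step that the limit leaves unreadable from compound 1 to compound 4 reflects this. Compound 4 is expected to come out at 100000 nM, with a plausible range from 30000 nM to 400000 nM, and most probably as another limit rather than a number.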

Compound 4, minimum cytotoxic concentration: 80000 nM
The estimate for compound 4 lay 1.3-fold (0.10 log units) above the measured number; measured number inside the range.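

In this assay compound 1 stands at a limit, >= 50000 nM, and not at a number. The step between compound 1 and compound 4 therefore cannot be read. The compounds shown leave open whether bromo in place of fluoro on an aromatic carbon changes the concentration tolerated at all.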